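The source may report more compounds than this note shows. Statements on the series, on what has been measured and on what is new or still open speak of the compounds shown alone.

Measured so far in a functional assay on the whole organism with Canis familiaris (Canis lupus familiaris) as the target; on this read-out higher numbers stand for an effect only at larger amounts of compound and lower numbers for an effect already at smaller amounts
- compound 1 `CCCOc1cc(OC)ccc1-c1nc2cc[nH]cc-2n1` gives 1.3 mg/kg
- compound 2 `CCOc1cc([S+](C)[O-])ccc1-c1nc2cc[nH]cc-2n1` gives 0.1 mg/kg
- compound 3 `CCOc1cc(S(C)(=O)=O)ccc1-c1nc2cc[nH]cc-2n1` gives 0.07 mg/kg

Not yet measured: compound 4 `CCCOc1cc([S+](C)[O-])ccc1-c1nc2cc[nH]cc-2n1`

In this set, compound 2 sits second highest of the three numbers, within the scatter of compound 3 and far under compound 1. Compound 4 differs from compound 2 only in the ether chain, ethoxy to propoxy: methyl in place of hydrogen on a saturated chain carbon, two bonds along the chain from an oxygen on an aromatic ring. Among the measured compounds shown here, no measured step covers this change. For the measured compounds named here, the one step available, a 1.4-fold lower number from compound 2 to compound 3 (0.15 log units; within the scatter), lies at another place on the ring and stays within the scatter. Compound 1 also carries propoxy and gives 1.3 mg/kg in this assay, but it differs from compound 2 at the other ring group as well, so it cannot isolate the chain. Only a weak lean towards a higher number is therefore expected, and the expected step, a 1.5-fold higher number from compound 2 to compound 4 (0.18 log units; within the scatter), stays within the scatter. The estimate for compound 4 is 0.15 mg/kg, with an expected range from 0.05 mg/kg to 0.5 mg/kg.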

Compound 4, dose for half-maximal effect: 1 mg/kg
Compound 4: the middle estimate sits 6.7-fold (0.82 log units) below what was measured; measured number outside the range, above it.
By their numbers in this assay, from the lowest: compounds 3 and 2 (each within the scatter of the next); then compounds 4 and 1 (each within the scatter of the next).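

In this assay, the ether chain proves to be a sensitive place in the series: ethoxy to propoxy, methyl in place of hydrogen on a saturated chain carbon, gives a 10-fold higher number from compound 2 to compound 4 (1.00 log units; beyond the scatter). With propoxy held constant, the change at the other ring group gives a 1.3-fold lower number from compound 1 to compound 4 (0.11 log units; within the scatter), so this pair shows no separable effect of that group, a comparison compound 1 could not offer alone. Nothing available accounts for the size of the chain step.

The compounds shown leave open whether the number keeps rising with a butoxy chain, or how a methoxy group or a branched isopropoxy group compares with ethoxy. From the compounds shown here alone, it also remains open whether propoxy carries the same penalty alongside the methylsulfonyl group of compound 3.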